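The compounds below may be only part of what the source reports. "The series", "measured", "known", "first", "only" and "open" are said of these compounds alone.

The four compounds share one amide core, drawn out as `O=C(Nc1cccc(Cl)c1)c1ccccc1O` for compound 2. In an assay for inhibition of HSP60/HSP10 (Homo sapiens), with a stated time of 60 min (on this read-out higher numbers stand for weaker inhibition and lower numbers for stronger inhibition), compound 2 reaches only the limit of the assay, > 100000 nM, so no number is known for it and it stands at the weak end of what has been measured. Compound 3, `COc1ccccc1C(=O)Nc1cccc(Cl)c1`, with methyl in place of hydrogen on an oxygen on an aromatic ring, likewise sits at a limit in this assay, > 100000 nM. The step from compound 2 to compound 3 is therefore a step that the two limits leave unreadable from compound 2 to compound 3; both sit at the limit of > 100000 nM in this assay, at which 2 of the 3 values shown sit. Compound 1, `O=C(Nc1cccc(Cl)c1)c1cc(Br)cc(Br)c1O`, carries dibromo substitution on the hydroxy-bearing ring, and in this assay compound 1 gives 29000 nM, a real number rather than a limit. Compound 4, `O=C(Nc1cccc(Cl)c1)c1cc(Br)ccc1O`, is not yet measured; it differs from compound 2 by bromo in place of hydrogen on an aromatic carbon. Among the measured compounds shown here, no measured step matches this single change; the only measured step, from compound 2 to compound 3, is unreadable and concerns a different place. Because compound 1 gives 29000 nM, bromo in place of hydrogen appears to go with a readable number, and the change to compound 4 is expected to be a step of an at least 1.6-fold lower number from compound 2 to compound 4 (0.22 log units; that floor lies within the scatter). The estimate for compound 4 in this assay is thus 60000 nM, within 25000 nM to 150000 nM, with a fair chance that only a limit is reported again.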

Compound 4, half-maximal inhibitory concentration: > 100000 nM
Compound 4 ended at the assay's limit; the forecaster's own chance of this, stated with the estimate: 40%; at least 1.6-fold (0.22 log units) between middle value and limit.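

A single bromo on the aromatic carbon para to a hydroxy group does not bring compound 4 off the limit of this assay, and the steps from compound 2 to compound 3 and from compound 2 to compound 4 cannot be read, as each joins two limits. The step that can be read takes the second bromo off compound 1 and leaves hydrogen in its place: it is an at least 3.4-fold higher number from compound 1 to compound 4 (0.53 log units; beyond the scatter). Among the compounds shown, a real number therefore appears only with both bromo groups present, while compound 4, with one, remains the third compound at a limit: the limit of > 100000 nM in this assay, at which 3 of the 4 values shown sit.

Still open, going by these compounds, is whether the other bromo of compound 1, on its own and with hydrogen on the carbon para to the hydroxy group, would give a real number, or whether only the two together do. Also open, on these data alone, is whether a different group on the carbon para to the hydroxy group, such as an amine or a carboxylic acid, would give a number in this assay.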